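Oxetan-3-yl in place of bromo on compound 3

The compounds below may be only part of what the source reports. "The series", "measured", "known", "first", "only" and "open" are said of these compounds alone.

Compound 3 `C[C@@H]1CN(c2sc(Br)nc2-c2nc3ccccc3[nH]2)CCN1C(=O)Cn1cnc2cccnc21` gives 526 nM in an assay on blood for inhibition of C-X-C chemokine receptor type 3 (Homo sapiens), with a stated time of 30 min (a higher number here means a weaker inhibitor, a lower number a stronger inhibitor), the lowest number among the three measured, though compound 1 `C[C@@H]1CN(c2scnc2-c2nc3ccccc3[nH]2)CCN1C(=O)Cn1cnc2cccnc21` with 554 nM and compound 2 `Cc1nc(-c2nc3ccccc3[nH]2)c(N2CCN(C(=O)Cn3cnc4cccnc43)[C@H](C)C2)s1` with 1060 nM both sit within the scatter of it. Compound 4 `C[C@@H]1CN(c2sc(C3COC3)nc2-c2nc3ccccc3[nH]2)CCN1C(=O)Cn1cnc2cccnc21` differs from compound 3 in one place: oxetan-3-yl in place of bromo on an aromatic carbon. The same aromatic carbon has already carried hydrogen, methyl and bromo, and every step among them stayed within the scatter: a 1.1-fold lower number from compound 1 to compound 3 (0.02 log units; within the scatter), a 2.0-fold lower number from compound 2 to compound 3 (0.30 log units; within the scatter) and a 1.9-fold higher number from compound 1 to compound 2 (0.28 log units; within the scatter). No measured step covers oxetan-3-yl itself, so the expectation rests on the tolerance this position has shown. The expected step is a 1.1-fold higher number from compound 3 to compound 4 (0.06 log units; within the scatter), no direction beyond the scatter. Compound 4 is estimated at 600 nM, range 300 nM to 1300 nM.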

Compound 4, half-maximal inhibitory concentration: 1150 nM
For compound 4 the middle estimate is 1.9-fold (0.28 log units) below the measured one; the range from low to high includes it.
By their numbers in this assay, from the lowest: compounds 3, 1, 2 and 4 (each within the scatter of the next, the first and the last beyond it).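

In this assay, going by these compounds alone, oxetan-3-yl is the first group on this aromatic carbon to give steps beyond the scatter, both modest: a 2.2-fold higher number from compound 3 to compound 4 (0.34 log units; beyond the scatter) and a 2.1-fold higher number from compound 1 to compound 4 (0.32 log units; beyond the scatter). Against methyl the change stays within the scatter, a 1.1-fold higher number from compound 2 to compound 4 (0.04 log units; within the scatter), so the tolerance at this position is narrowed only slightly. Nothing available bears on why this step occurs.

As far as these compounds go, whether the step goes with the ring oxygen or with the four-membered ring remains open; cyclobutyl would separate the two. From the compounds shown here alone, how an amine or a carboxylic acid on this carbon would read also stays open.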